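The source may report more compounds than this note shows. Statements on the series, on what has been measured and on what is new or still open speak of the compounds shown alone.

Working notes on the series. Compound 1 `COc1ccc(C(=O)NCc2ccc(CNS(=O)(=O)c3ccc(C)cc3)cc2)cc1` gives 100 nM in an assay on MDA-MB-231 cells for binding affinity to C-X-C chemokine receptor type 4 (Homo sapiens), read by immunofluorescence and microscopy, with stated times of 10 min and 30 min; on this read-out higher numbers stand for an effect only at larger amounts of compound and lower numbers for an effect already at smaller amounts; compound 2 `O=C(NCc1ccc(CNS(=O)(=O)c2ccccc2)cc1)c1ccc([N+](=O)[O-])cc1` gives 100 nM in this assay; compound 3 `Cc1ccc(S(=O)(=O)NCc2ccc(CNC(=O)c3ccncc3)cc2)cc1` gives 10 nM in this assay. Compound 3 thus stands at the lowest number of the three, and its steps to both compound 1 and compound 2 are beyond the scatter. Among the compounds with values here, only one single-place step is available: a 10-fold lower number from compound 1 to compound 3 (1.00 log units; beyond the scatter). Compound 2 differs from compound 3 in more than one place, so for that pair only the two values themselves can be set side by side.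

Compound 4 `Cc1ccc(S(=O)(=O)NCc2ccc(CNC(=O)c3ccc(Cl)cc3)cc2)cc1` carries a carbon-only ring on the carbonyl carbon again: 4-chlorophenyl in place of pyridin-4-yl on a carbonyl carbon. The measured step that bears on this change is the one running the other way, from a substituted phenyl to pyridin-4-yl, and it gave a 10-fold lower number from compound 1 to compound 3 (1.00 log units; beyond the scatter). Within the data shown here, compound 4 is therefore expected to give a higher number in this assay than compound 3, roughly the reverse of that step, though 4-chlorophenyl is not 4-methoxyphenyl and no measured pair isolates that difference, so the expectation is loose. The expected step is a 6.0-fold higher number from compound 3 to compound 4 (0.78 log units; beyond the scatter). The estimate for compound 4 in this assay is 60 nM, with a range from 20 nM to 200 nM.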

Compound 4, effective concentration (reported as EC, without a stated level of effect): 10 nM
Compound 4: middle estimate off by 6.0-fold (0.78 log units), on the high side, outside the stated range (below it).
By their numbers in this assay, from the lowest: compounds 3 and 4 (each within the scatter of the next); then compounds 1 and 2 (each within the scatter of the next).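

In this assay the ring nitrogen of pyridin-4-yl turns out not to be required on this carbonyl carbon: no change at the digits printed from compound 3 to compound 4 (within the scatter) shows that 4-chlorophenyl, a ring of carbon only with no hydrogen-bond acceptor, sits level with pyridin-4-yl. The earlier step from the methoxy compound to the pyridine therefore no longer reads as a contrast between a carbon-only ring and a nitrogen-containing ring, as a 10-fold lower number from compound 1 to compound 4 (1.00 log units; beyond the scatter) spans the same gap with a carbon-only ring at both ends, through chloro in place of methoxy on an aromatic carbon. Among these three compounds, the higher number belongs to compound 1 with its 4-methoxyphenyl group, and no measurement shown here accounts for that difference.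

Going by these compounds, it remains open whether the methoxy result extends to other groups at that aromatic carbon, such as hydroxyl, ethoxy or dimethylamino, or whether fluoro or bromo would match chloro. Also open, on these data alone, is whether an aromatic ring is needed on the carbonyl carbon at all, as a cyclohexyl or piperidin-4-yl group would test.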